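Swapping Trifluoromethoxy for Sulfamoyl on a Shared Core

The source may hold more compounds than are shown below. What is called first, only, known or untested is meant among the compounds shown, and "the series" means these compounds.

Measured compounds:
Compound 1, `O=C1C(Nc2ccc(OC(F)(F)F)cc2)=CC(=O)c2ncncc21`: 1400 nM
Compound 2, `Nc1ccc(-c2ccc(NC3=CC(=O)c4ncncc4C3=O)cc2)cc1`: 2500 nM

In a functional assay on MIA PaCa-2 cells (Homo sapiens) for cytotoxicity, read by MTT assay, with a stated time of 72 h (on this read-out higher numbers stand for weaker inhibition and lower numbers for stronger inhibition), compound 1 gives 1400 nM. Within the data shown here, the only other number belongs to compound 2, which gives 2500 nM, and the step of a 1.8-fold higher number from compound 1 to compound 2 (0.25 log units; within the scatter) lies within the usual scatter, so the two compounds stand level and neither can be called the stronger.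

Compound 3, `NS(=O)(=O)c1ccc(NC2=CC(=O)c3ncncc3C2=O)cc1`, differs from compound 1 by sulfamoyl in place of trifluoromethoxy on an aromatic carbon. Among the measured compounds shown here, the one measured step that bears on this change is a 1.8-fold higher number from compound 1 to compound 2 (0.25 log units; within the scatter), where the same trifluoromethoxy was exchanged for a different group without moving the number beyond the scatter. For the measured compounds named here, with only that step to go on, the exchange for sulfamoyl is expected to give a step of a 1.4-fold higher number from compound 1 to compound 3 (0.15 log units; within the scatter) of no more than the scatter. Compound 3 is therefore estimated at 2000 nM, with a range from 800 nM to 5000 nM.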

Compound 3, half-maximal inhibitory concentration: > 10000 nM
Compound 3: no number, only a limit (the forecaster's own chance of this, stated with the estimate: 5%); middle value at least 5.0-fold (0.69 log units) from the limit.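

In this assay compound 3 gives > 10000 nM, which is a limit of the assay and not a number. Even so, the limit is enough to fix two steps, an at least 7.1-fold higher number from compound 1 to compound 3 (0.85 log units; beyond the scatter) and an at least 4.0-fold higher number from compound 2 to compound 3 (0.60 log units; beyond the scatter), and both lie beyond the scatter. The earlier compounds shown here stood level despite the large difference between trifluoromethoxy and 4-aminophenyl, so they could have suggested that this aromatic carbon tolerates many groups, whereas sulfamoyl shows that the group placed here can weaken the read-out.

On these data alone, how much weaker compound 3 really is stays open: the limit of > 10000 nM in this assay, at which 1 of the 3 values shown sits. It also remains open whether the loss is specific to sulfamoyl or would also appear with a carboxylic acid or a methylsulfonyl group on the same aromatic carbon of the shared core.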